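Compound 3: chloro in place of nitro

The compounds below may be only part of what the source reports. "The series", "measured", "known", "first", "only" and "open" are said of these compounds alone.

Values in a functional assay on MCF7 cells (Homo sapiens) for inhibition, read by MTT assay, with a stated time of 48 h, tested at 10 uM (a lower number here means less inhibition of growth, a higher number more inhibition of growth at the concentration tested), are as follows
Compound 1 `Cc1cc(=O)c2c(O)c(CN(C(C)C)C(C)C)c(O)c([C@H]3CCN(C)C[C@H]3O)c2o1` gives 33%
Compound 2 `Cc1oc2c([C@H]3CCN(C)C[C@H]3O)c(O)cc(O)c2c(=O)c1C(O)c1ccc([N+](=O)[O-])cc1` gives 4%

Compound 2 holds the lower of the two numbers, and compound 1 lies above it by a gap beyond the scatter. These two compounds differ in more than one place, so their gap gives no guide to the next change. Compound 3 `Cc1oc2c([C@H]3CCN(C)C[C@H]3O)c(O)cc(O)c2c(=O)c1C(O)c1ccc(Cl)cc1` carries chloro in place of nitro on an aromatic carbon, para to a large group, turning the 4-nitrophenyl of compound 2 into 4-chlorophenyl (chloro in place of nitro on an aromatic carbon). Going by the values given here, no measured pair isolates this change. With compound 2 at 4% there is little room downward, so a small upward step, not beyond the scatter, is expected (a number 8 percentage points higher from compound 2 to compound 3 (within the scatter)). The estimate for compound 3 is 12% (expected range 0% to 30%).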

Compound 3, percent growth inhibition at one concentration: 6%
For compound 3 the middle estimate is 6 percentage points above the measured one; the range from low to high includes it.
By their numbers in this assay, from the lowest: compounds 2 and 3 (each within the scatter of the next); then compound 1.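

In this assay, going by these compounds alone, chloro in place of nitro on this aromatic carbon gives a number 2 percentage points higher from compound 2 to compound 3 (within the scatter), the only step so far that isolates a single change. Nitro, with its hydrogen-bond acceptors and double bond, and chloro, a single heavy atom with no acceptors, therefore cannot be told apart at this position in this read-out, and the 4-chlorophenyl and 4-nitrophenyl compounds stand together at the low end of the series. No measurement on hand bears on why these two substituents read alike.

From the compounds shown here alone, whether an amine or a carboxylic acid on the same aromatic carbon would move the number beyond the scatter stays open. Compound 1 differs from compound 2 and compound 3 in more than one place, and its gaps to them cannot be read as steps.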